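The source may hold more compounds than are shown below. What is called first, only, known or untested is meant among the compounds shown, and "the series" means these compounds.

Compound 1 `COc1ccccc1/C=c1/[nH]c(=O)/c(=C\c2ccccc2OC)[nH]c1=O`: in a functional assay on MOLT-4 cells (Homo sapiens) for cytotoxicity, read by CCK-8 assay, with a stated time of 72 h (a lower number here means a stronger inhibitor, a higher number a weaker inhibitor), compound 1 gives "not determined" (no result reported).
Compound 2 `C=CCn1c(=O)/c(=C\c2ccc(Cl)c(Cl)c2)[nH]c(=O)/c1=C\c1ccccc1`: in this assay compound 2 gives "not active" (no number reported).
Compound 3 `C=CCn1c(=O)/c(=C\c2cccc(F)c2)[nH]c(=O)/c1=C\c1ccccc1OC`: in this assay compound 3 gives 6500 nM.

For the measured compounds named here, compound 3 holds the only number in this set; compound 1 and compound 2 give no figure to set beside it, so there is nothing to rank compound 3 against. Compound 4 `C=CCn1c(=O)/c(=C\c2cccc(Br)c2)[nH]c(=O)/c1=C\c1ccccc1OC` differs from compound 3 in one place: bromo in place of fluoro on an aromatic carbon. Going by the values given here, no pair of measured compounds shows what such an exchange does in this assay, so any expectation rests on the single value of compound 3 and the small size of the change. A step no larger than the usual scatter is expected, with a slight lean toward a stronger inhibitor: the expected step is a 1.3-fold lower number from compound 3 to compound 4 (0.11 log units; within the scatter). Compound 4 is therefore estimated at 5000 nM, within a range of 2000 nM to 15000 nM.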

Compound 4, half-maximal inhibitory concentration: 5000 nM
Estimate against measurement, compound 4: no gap at the digits printed; low and high end bracket the measured number.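

In this assay, for the compounds shown here, the exchange of 3-fluorophenyl for 3-bromophenyl gives a 1.3-fold lower number from compound 3 to compound 4 (0.11 log units; within the scatter) and so offers the first direct comparison at this position. The two halogens cannot be told apart here, and cytotoxicity survives the exchange. No available measurement explains this result. Still open, on these data alone, is whether an amine or a carboxylic acid at this same ring position would keep the cytotoxicity. A single pair also cannot show whether bromo and fluoro would match as closely on other compounds with the shared core.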